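From a Methylpiperidine Chain to a Pyrrolidine Ring

The source may report more compounds than this note shows. Statements on the series, on what has been measured and on what is new or still open speak of the compounds shown alone.

Compound 1 `CN1CCC(Cn2c(N)nc3ccc(C(=O)c4ccccc4)cc32)CC1` and compound 2 `CN1CCC(CCn2c(N)nc3ccc(C(=O)c4ccccc4)cc32)CC1` share one core. In an ADME assay on HL-60 cells (Homo sapiens) for cytotoxicity, read by resazurin assay, with a stated time of 72 h (a lower number here means that less compound is needed, a higher number that more compound is needed for the effect), compound 1 gives only a limit of > 30000 nM. In this assay compound 2 likewise gives only a limit of > 30000 nM. Within the data shown here, the single measured step, a step that the two limits leave unreadable from compound 1 to compound 2, cannot be read, as the limit of > 30000 nM in this assay, at which 2 of the 2 values shown sit, shows. Compound 3 `Nc1nc2ccc(C(=O)c3ccccc3)cc2n1C[C@H]1CCCN1` is not yet measured and differs from compound 2 by pyrrolidin-2-yl in place of (1-methylpiperidin-4-yl)methyl on a saturated chain carbon bound to an aromatic nitrogen. Among the measured compounds shown here, no measured step bears on this change, so no direction can be drawn from the data. Compound 3 is expected to sit near 30000 nM, within 8000 nM to 100000 nM. The step is therefore estimated as a number no higher from compound 2 to compound 3 (the limit leaves the size open).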

Compound 3, half-maximal effective concentration: > 30000 nM
Compound 3 gave a limit, no number; the forecaster's own chance of this, stated with the estimate: 75%; the middle value sits exactly at the limit.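

Among these compounds, compound 3, like compound 1 and compound 2, gives only a limit in this assay and no step among the three can be read: the limit of > 30000 nM in this assay, at which 3 of the 3 values shown sit. The compounds shown leave open whether any group at this place changes the half-maximal effective concentration at all.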